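A few compounds are considered here, and "the series" means these few. Any claim that something is new, unique, unknown or untested is made for them only; others in the source may bear on it.

Compound 1 `CCN1CCN(c2cc(C)c3cc(NC(=O)c4ccc5ccccc5n4)ccc3n2)CC1` gives the lowest number of the three measured compounds: in a functional assay on SK-BR-3 cells (Homo sapiens) for antiproliferative activity, read by MTT assay, with a stated time of 72 h (on this read-out higher numbers stand for weaker inhibition and lower numbers for stronger inhibition), compound 1 gives 3760 nM, while compound 3 `CNc1cc(C)c2cc(NC(=O)c3ccc(Cl)c(Cl)c3)ccc2n1` gives 6350 nM and compound 2 `Cc1cc(NCCN2CCCC2)nc2ccc(NC(=O)c3ccc(Cl)c(Cl)c3)cc12` gives 9530 nM. The gap between compound 1 and compound 3 lies within the scatter, the gap to compound 2 beyond it. Compound 4 `CCN1CCN(c2cc(C)c3cc(NC(=O)c4ccc[nH]4)ccc3n2)CC1` differs from compound 1 by 1H-pyrrol-2-yl in place of quinolin-2-yl on a carbonyl carbon. Going by the values given here, the one measured step, a 1.5-fold lower number from compound 2 to compound 3 (0.18 log units; within the scatter), concerns a different part of the molecule and does not bear on an exchange of the aryl group on the carbonyl carbon; no measured pair shows that exchange. The step is therefore expected to be a 2.4-fold higher number from compound 1 to compound 4 (0.38 log units; beyond the scatter), a weakening of inhibition. Compound 4 is estimated at 9000 nM, within 3000 nM to 30000 nM.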

Compound 4, half-maximal inhibitory concentration: 13200 nM
Beside the measured number, compound 4's estimate is 1.5-fold (0.17 log units) below it; measured number inside the range.
By their numbers in this assay, from the lowest: compounds 1, 3, 2 and 4 (each within the scatter of the next, the first and the last beyond it).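

In this assay, going by these compounds alone, 1H-pyrrol-2-yl in place of quinolin-2-yl on the carbonyl carbon gives a 3.5-fold higher number from compound 1 to compound 4 (0.55 log units; beyond the scatter), a weakening of inhibition, so this position responds to the exchange, whereas the one earlier step, made elsewhere in the molecule, stayed within the scatter. The exchange alters ring count, size and hydrogen-bond donor count together, and this single pair cannot separate them. Nothing available gives a reason for the step. Going by these compounds, it remains open whether a phenyl or 1-methylpyrrol-2-yl group on the carbonyl carbon would give a number nearer that of compound 1 or that of compound 4.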